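A few compounds are considered here, and "the series" means these few. Any claim that something is new, unique, unknown or untested is made for them only; others in the source may bear on it.

- compound 1 (`CN1CCN(c2ccc(N/C=C3\C(=O)NC(=O)c4ccc(-c5ccoc5)cc43)cc2)CC1`) gives 1100 nM
- compound 2 (`O=C1NC(=O)c2ccc(-c3ccoc3)cc2/C1=C/Nc1ccc(CN2CCCCC2)cc1`) gives 1100 nM

Going by the values given here, in a functional assay on MCF7 cells (Homo sapiens) for antiproliferative activity, read by sulforhodamine B assay (a higher number here means a weaker inhibitor, a lower number a stronger inhibitor), compound 1 gives 1100 nM and stands level with compound 2, the only other compound measured so far. The next compound to be tested, compound 3 (`CN1CCN(c2ccc(N/C=C3\C(=O)NC(=O)c4ccc(-c5ccoc5)cc43)cc2F)CC1`), is compound 1 with a single edit: fluoro in place of hydrogen on an aromatic carbon (fluoro in place of hydrogen on an aromatic carbon, ortho to a 4-methylpiperazin-1-yl group).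

Among the compounds with values here, the only measured step is no change at the digits printed from compound 1 to compound 2 (within the scatter) and it involves a different swap, (piperidin-1-yl)methyl in place of 4-methylpiperazin-1-yl on an aromatic carbon. Within the data shown here, that step shows one replacement of the 4-methylpiperazin-1-yl group that left the read-out unmoved, but no measured pair shows what adding fluoro does. The evidence is therefore thin, and the fair expectation is no shift beyond the scatter, with real uncertainty in both directions.

The expected move is no change at the digits printed from compound 1 to compound 3 (within the scatter) and neither direction is favoured. For compound 3 the estimated value is 1100 nM with an expected range from 450 nM to 2700 nM in this test.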

Compound 3, half-maximal inhibitory concentration: 900 nM
For compound 3 the middle estimate is 1.2-fold (0.09 log units) above the measured one; the measured number falls inside the stated range.
By their numbers in this assay, from the lowest: compounds 3, 1 and 2 (each within the scatter of the next).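

In this assay, going by these compounds alone, the first measured look at fluoro in place of hydrogen on this aromatic carbon, ortho to a 4-methylpiperazin-1-yl group, shows a 1.2-fold lower number from compound 1 to compound 3 (0.09 log units; within the scatter) and this step lies within the usual scatter of repeated measurements. The position therefore accepts a fluoro without a read-out that can be told apart from that of compound 1, so an edit on the aromatic carbon beside the group's attachment joins the swap of that group for (piperidin-1-yl)methyl in compound 2 as a change that leaves the number where it was. No other measurement is available that would explain why the read-out holds at this position.

From the compounds shown here alone, whether a chlorine, a methoxy group or an amine on this same carbon would move the number beyond the scatter remains open, since a single fluoro says nothing about those groups. Also open, going by these compounds, is whether fluoro on another carbon of this ring, or on the ring of compound 2, would leave the read-out just as steady.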